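The source may hold more compounds than are shown below. What is called first, only, known or untested is meant among the compounds shown, and "the series" means these compounds.

In an ADME assay on MT4 cells (Homo sapiens) for cytotoxicity, read by MTT assay, with a stated time of 5 days (on this read-out lower numbers stand for higher toxicity in this test and higher numbers for lower toxicity in this test), compound 1 (`Cc1cccc(C)c1Oc1cc(Nc2ccc(C#N)cc2)[nH]c(=O)c1Br`) gives 63000 nM and compound 2 (`Cc1cc(C)c(Oc2cc(Nc3ccc(C#N)cc3)[nH]c(=O)c2)c(C)c1`) gives 32000 nM, two numbers that lie within the usual scatter of each other. Compound 3 (`Cc1cc(C)c(Oc2cc(Nc3ccc(C#N)cc3)[nH]c(=O)c2Br)c(C)c1`) departs from compound 2 in one place: bromo in place of hydrogen on an aromatic carbon. Going by the values given here, no measured pair isolates this change, but compound 1 also carries bromo and gives 63000 nM, so no shift beyond the scatter is expected in this assay. The estimated step of a 1.1-fold higher number from compound 2 to compound 3 (0.04 log units; within the scatter) is accordingly small. For compound 3 the expected value is 35000 nM, within an estimated range of 12000 nM to 95000 nM.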

Compound 3, half-maximal cytotoxic concentration: > 294000 nM
Compound 3: a limit, no number; the forecaster's own chance of this, stated with the estimate: 10%; middle value at least 8.4-fold (0.92 log units) from the limit.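

In this assay, going by these compounds alone, bromo in place of hydrogen on this aromatic carbon, two atoms from the ring nitrogen, gives an at least 9.1-fold higher number from compound 2 to compound 3 (0.96 log units; beyond the scatter), the first step beyond the scatter at this position. A second change, an added methyl group, gives an at least 4.6-fold higher number from compound 1 to compound 3 (0.66 log units; beyond the scatter), so compound 3 also stands apart from the other bromo compound. Compound 3 sits at a limit of the assay, not at a number: the limit of > 294000 nM in this assay, at which 1 of the 3 values shown sits.

On these data alone, how far the true value of compound 3 lies past this limit stays open. As far as these compounds go, whether chloro or an amine on this carbon would give a step of similar size also stays open.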